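Propargyl to Cyclopropyl on the Amide: Toxicity Unchanged

The source may hold more compounds than are shown below. What is called first, only, known or untested is meant among the compounds shown, and "the series" means these compounds.

Measured so far in a toxicity assay on the whole organism (strain Icem-CET (SPF Caw)) for cytotoxicity, with Mus musculus as the target; a lower number here means that less compound is needed, a higher number that more compound is needed for the effect:
compound 1, `C#CCNC(=O)/C(C)=C(\C)c1cc(OC)c(OC)c(OC)c1`, gives 150 mg/kg
compound 2, `C#CCNC(=O)/C(C)=C(\C)c1ccccc1`, gives 150 mg/kg
compound 3, `C/C(C(=O)NC1CC1)=C(/C)c1ccccc1`, gives 150 mg/kg

Compounds 2 and 3 share one core and differ only at the amide nitrogen: cyclopropyl in place of propargyl on an amide-type nitrogen. In this assay this gives no change at the digits printed from compound 2 to compound 3 (within the scatter). Among the compounds with values here, compound 1 stands level with both of them; how its core differs from the core of compound 2 is not broken down here, and of that pair one can say only that their two values are alike.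

The unmeasured compound 4, `COc1cc(/C(C)=C(\C)C(=O)NC2CC2)cc(OC)c1OC`, carries the core of compound 1 and bears the same change that leads from compound 2 to compound 3: cyclopropyl in place of propargyl on an amide-type nitrogen. The place is worded identically in both pairs, so it is the same change.

Because no change at the digits printed from compound 2 to compound 3 (within the scatter) on the core of compound 2 was flat, and because compound 1 sits at 150 mg/kg, level with compound 2, the step from compound 1 to compound 4 in this assay is expected to be equally flat, no change at the digits printed from compound 1 to compound 4 (within the scatter). This rests on a single measured occurrence of the change, so the expectation is held loosely. For compound 4 in this assay the estimate is 150 mg/kg, expected to fall between 75 mg/kg and 300 mg/kg.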

Compound 4, dose for half-maximal effect: > 800 mg/kg
Compound 4: a limit, no number (the forecaster's own chance of this, stated with the estimate: 15%); middle value at least 5.3-fold (0.72 log units) away from the limit.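

In this assay compound 4 gives > 800 mg/kg, which is a limit of the assay and not a number. Cyclopropyl in place of propargyl on an amide-type nitrogen gives an at least 5.3-fold higher number from compound 1 to compound 4 (0.72 log units; beyond the scatter), but no change at the digits printed from compound 2 to compound 3 (within the scatter), so in these two pairs the change did not carry from one core to the other at the same size: the same change on two cores in this assay, no change at the digits printed (within the scatter) from compound 2 to compound 3 and an at least 5.3-fold higher number (0.72 log units; beyond the scatter) from compound 1 to compound 4, at least 5.3-fold (0.72 log units) apart, beyond the scatter of two such steps. Within the data shown here, this does not show how large the higher step truly is, which feature of the core of compound 1 sets the two pairs apart, or whether the result holds on any further core, since each core supplies only one pair and one value stands at a limit: the limit of > 800 mg/kg in this assay, at which 1 of the 4 values shown sits.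

The compounds shown leave open whether the jump belongs to the three-membered ring itself or simply to the loss of propargyl, which an open ethyl or propyl chain, or a larger cyclobutyl ring, on the same amide nitrogen of the core of compound 1 could help to separate. Also open, on these data alone, is whether a core carrying a single methoxy group would behave like the pair of compound 2 and compound 3 or like the pair of compound 1 and compound 4.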